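A few compounds are considered here, and "the series" means these few. Any claim that something is new, unique, unknown or untested is made for them only; others in the source may bear on it.

The measured compounds:

Compound 1 `Oc1nc2nonc2nc1Nc1ccc(OCc2ccccc2)cc1` gives 2400 nM in an assay on mitochondria from L6 cells (Rattus norvegicus) for activation, with a stated time of 90 min; a higher number here means that more compound is needed for the effect, a lower number that less compound is needed.
Compound 2 `Oc1nc2nonc2nc1Nc1cccc(F)c1` gives 31200 nM in this assay.
Compound 3 `Oc1nc2nonc2nc1NCCC(F)(F)F` gives 110000 nM in this assay.

For the measured compounds named here, of these three, compound 1 has the lowest number in this assay; compound 2 and compound 3 both sit higher, and in each case the gap lies beyond the usual scatter, so compound 1 is the one that needs least compound for the effect. Compound 2, which carries a fluorine on the aromatic ring in place of the benzyloxy group, and compound 3, which has no aromatic ring on the amine at all, are clearly weaker.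

The unmeasured compound 4 `Oc1nc2nonc2nc1Nc1ccc(OC(F)(F)C(F)F)cc1` keeps the shared core and the amino-linked aromatic ring of compound 1 but alters the group on the ring oxygen: 1,1,2,2-tetrafluoroethyl in place of benzyl on an oxygen on an aromatic ring. Going by the values given here, no pair of measured compounds differs in just this one place, so the size of the step has to be judged from the spread of the three numbers alone. The loss of the benzyl ring is expected to cost some activity, and compound 4 is expected to show a moderate rise in the number from compound 1, a 2.9-fold higher number from compound 1 to compound 4 (0.46 log units; beyond the scatter), though smaller than the gap to compound 2. Compound 4 is therefore estimated at 7000 nM, within a range of 1800 nM to 28000 nM.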

Compound 4, half-maximal effective concentration: 7000 nM
Compound 4: the middle estimate sits on the measured number at the digits printed; low and high end bracket the measured number.
By their numbers in this assay, from the lowest: compound 1; then compound 4; then compound 2; then compound 3.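

For the compounds shown here, putting 1,1,2,2-tetrafluoroethyl in place of benzyl on an oxygen on an aromatic ring gives a 2.9-fold higher number from compound 1 to compound 4 (0.46 log units; beyond the scatter) in this assay and is the first step here between measured compounds that differ in one place. The step is modest but lies beyond the scatter, so the oxygen substituent does affect the number, yet a group with no ring, made of 2 carbon and 4 fluorine atoms, takes the place of the benzyl group at only a modest cost in this assay and leaves compound 4 at 7000 nM in this series. Nothing measured here accounts for the size or direction of this step.

The change removes the aromatic ring and brings in the fluorines at once, and the compounds shown do not separate these two parts of the step. They also leave open how a plain ethyl group, a methyl group or a cyclohexylmethyl group on the same oxygen would read in this assay, and whether any of these would fall closer to compound 1 or to compound 4.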